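Halogen pattern on the hydrazone aryl ring in PC-3 cells

The compounds below may be only part of what the source reports. "The series", "measured", "known", "first", "only" and "open" are said of these compounds alone.

Three analogues sharing the core of compound 1 `Cn1c(=O)c(=O)n(C2CCCC2)c2nc(N/N=C/c3ccc(Cl)cc3)ncc21` have been read in a functional assay on PC-3 cells (Homo sapiens) for antiproliferative activity, read by MTT assay; on this read-out higher numbers stand for weaker inhibition and lower numbers for stronger inhibition. In this assay compound 1 gives 8420 nM; compound 2 `Cn1c(=O)c(=O)n(C2CCCC2)c2nc(N/N=C/c3ccc(F)c(Cl)c3)ncc21` gives 8550 nM and compound 3 `Cn1c(=O)c(=O)n(C2CCCC2)c2nc(N/N=C/c3ccc(F)cc3Cl)ncc21` gives 15200 nM. Compound 1 sits at the low end of the three numbers, but neither gap reaches beyond the scatter: the step of a 1.0-fold higher number from compound 1 to compound 2 (0.01 log units; within the scatter) and the step of a 1.8-fold higher number from compound 1 to compound 3 (0.26 log units; within the scatter) are both within it, as is the step of a 1.8-fold higher number from compound 2 to compound 3 (0.25 log units; within the scatter).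

Compound 4 `Cn1c(=O)c(=O)n(C2CCCC2)c2nc(N/N=C/c3ccc(F)cc3Br)ncc21` differs from compound 1 by 2-bromo-4-fluorophenyl in place of 4-chlorophenyl on a carbon with a double bond to nitrogen. The step that bears on it most directly is a 1.8-fold higher number from compound 1 to compound 3 (0.26 log units; within the scatter), where a chlorine sits where compound 4 carries bromine on the same 4-fluorophenyl pattern; the step of a 1.0-fold higher number from compound 1 to compound 2 (0.01 log units; within the scatter) adds that moving halogens about this ring has so far changed nothing beyond the scatter. A small rise in the number, if any, is therefore expected, a 1.5-fold higher number from compound 1 to compound 4 (0.19 log units; within the scatter), with no step beyond the scatter. In this assay compound 4 is estimated at 13000 nM, within 6000 nM to 28000 nM.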

Compound 4, half-maximal inhibitory concentration: 9250 nM
The estimate for compound 4 lay 1.4-fold (0.15 log units) above the measured number; the measured number falls inside the stated range.
By their numbers in this assay, from the lowest: compounds 1, 2, 4 and 3 (each within the scatter of the next).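

Bromo in place of chloro on an aromatic carbon is the only direct swap of one halogen for another shown here, and in this assay the step of a 1.6-fold lower number from compound 3 to compound 4 (0.22 log units; within the scatter) stays within the scatter, so no difference between these two halogens is resolved on this fluorinated ring. 2-Bromo-4-fluorophenyl also stays level with the other two aryl groups, with a 1.1-fold higher number from compound 1 to compound 4 (0.04 log units; within the scatter) and a 1.1-fold higher number from compound 2 to compound 4 (0.03 log units; within the scatter) both within the scatter, leaving all four halogen patterns on the carbon with a double bond to nitrogen indistinguishable in this read-out. Nothing available offers an explanation for these numbers.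

All four compounds carry only halogens on this ring. On these data alone, whether a plain phenyl, a methoxy group, an amine or a carboxylic acid here would give a step beyond the scatter remains open.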